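The source may hold more compounds than are shown below. What is called first, only, known or untested is meant among the compounds shown, and "the series" means these compounds.

Three compounds share one core and differ only in the aromatic group joined to the carbon with a double bond to nitrogen. Compound 1 `CN(C)CCn1cnnc1-c1cc(Oc2ccc(NC(=O)N/N=C/c3ccc(O)c(F)c3)cc2F)ccn1` gives 2620 nM in a functional assay on NCI-H460 cells (Homo sapiens) for cytotoxicity, read by MTT assay, with a stated time of 72 h; a lower number here means a stronger inhibitor, a higher number a weaker inhibitor. Compound 2 `CN(C)CCn1cnnc1-c1cc(Oc2ccc(NC(=O)N/N=C/c3ccc(O)cc3)cc2F)ccn1` gives 1780 nM in this assay, and the change from compound 1 is a 1.5-fold lower number from compound 1 to compound 2 (0.17 log units; within the scatter). Compound 3 `COc1ccc(/C=N/NC(=O)Nc2ccc(Oc3ccnc(-c4nncn4CCN(C)C)c3)c(F)c2)c(OC)c1` gives 1570 nM in this assay; the steps to it are a 1.7-fold lower number from compound 1 to compound 3 (0.22 log units; within the scatter) and a 1.1-fold lower number from compound 2 to compound 3 (0.05 log units; within the scatter). Among the measured compounds shown here, of the three numbers, the one for compound 3 is the smallest, yet each of its steps to the other two compounds stays within the scatter, so the three compounds cannot be separated on these data.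

Compound 4 `COc1ccc(/C=N/NC(=O)Nc2ccc(Oc3ccnc(-c4nncn4CCN(C)C)c3)c(F)c2)c(OC)c1OC` differs from compound 3 by methoxy in place of hydrogen on an aromatic carbon. The two steps that bear on this are those that also rework the 2,4-dimethoxyphenyl end, a 1.7-fold lower number from compound 1 to compound 3 (0.22 log units; within the scatter) and a 1.1-fold lower number from compound 2 to compound 3 (0.05 log units; within the scatter), and both stay within the scatter. The expected step in this assay is therefore a 1.0-fold lower number from compound 3 to compound 4 (0.02 log units; within the scatter), none beyond the scatter. Compound 4 is estimated at 1500 nM, within 700 nM to 3200 nM.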

Compound 4, half-maximal inhibitory concentration: 1790 nM
Beside the measured number, compound 4's estimate is 1.2-fold (0.08 log units) below it, and the stated range covers the measured number.
By their numbers in this assay, from the lowest: compounds 3, 2, 4 and 1 (each within the scatter of the next).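

Adding a methoxy group to the 2,4-dimethoxyphenyl end, on the aromatic carbon ortho to two methoxy groups, gives the 2,3,4-trimethoxyphenyl end, and in this assay this is a 1.1-fold higher number from compound 3 to compound 4 (0.06 log units; within the scatter). Against the 4-hydroxyphenyl and 3-fluoro-4-hydroxyphenyl ends, the new end gives a 1.0-fold higher number from compound 2 to compound 4 (0.00 log units; within the scatter) and a 1.5-fold lower number from compound 1 to compound 4 (0.17 log units; within the scatter), so a third methoxy group at this position brings no change that these data can separate, and the four compounds remain indistinguishable here. Nothing available explains why the numbers stay so close.

On these data alone, it remains open whether a different group at this position, such as an amine, a carboxylic acid or a longer alkoxy chain, would move the number beyond the scatter. As far as these compounds go, how a plain phenyl end would compare is also open.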